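Moving a chlorine on the phenyl ring of compound 2

A few compounds are considered here, and "the series" means these few. Any claim that something is new, unique, unknown or untested is made for them only; others in the source may bear on it.

Measured compounds:
compound 1, `Clc1ccc(-c2cc(-c3cccnc3)nc(-c3ccsc3)c2)o1`, 21700 nM
compound 2, `Clc1ccc(-c2cc(-c3cccs3)nc(-c3ccccc3Cl)c2)o1`, 17200 nM
compound 3, `Clc1ccc(-c2cc(-c3ccoc3)cc(-c3cccs3)n2)cc1`, 21100 nM

Of the compounds shown here, three have been tested in a functional assay on K562 cells (Homo sapiens) for cytotoxicity, in the presence of a further agent that is not named here; on this read-out higher numbers stand for weaker inhibition and lower numbers for stronger inhibition. Compound 1 gives 21700 nM, compound 2 gives 17200 nM and compound 3 gives 21100 nM. Compound 2 has the smallest of the three numbers, but its distance to compound 3 and its distance to compound 1 both lie within the usual scatter of this assay, so the three compounds stand level with one another, and no ordering among them can be read from these numbers.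

Compound 4, `Clc1ccc(-c2cc(-c3ccc(Cl)o3)cc(-c3cccs3)n2)cc1`, has not yet been tested in this assay. It differs from compound 2 in one place: 4-chlorophenyl in place of 2-chlorophenyl on an aromatic carbon.

Among the measured compounds shown here, no pair of measured compounds differing in a single place is available, so there is no measured step on which to build. The three measured compounds, which differ from one another in several places at once, all sit close together, and nothing in the data suggests that this rearrangement would carry compound 4 away from them. The step from compound 2 to compound 4 in this assay is therefore expected to be small, a 1.0-fold higher number from compound 2 to compound 4 (0.02 log units; within the scatter), in no particular direction and not beyond the scatter. Compound 4 is estimated at 18000 nM, with a range from 7000 nM to 45000 nM.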

Compound 4, half-maximal inhibitory concentration: 20900 nM
Compound 4: middle estimate off by 1.2-fold (0.06 log units), on the low side; the range from low to high includes it.
By their numbers in this assay, from the lowest: compounds 2, 4, 3 and 1 (each within the scatter of the next).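

In this assay, among the compounds shown here, the chlorine on the phenyl ring was moved, with 4-chlorophenyl in place of 2-chlorophenyl on the aromatic carbon next to the ring nitrogen, and this gives a 1.2-fold higher number from compound 2 to compound 4 (0.08 log units; within the scatter) as the first measured step at this position, which shows that the two chlorophenyl isomers stand level here. Compound 4 also supplies a second single-place comparison, in which 5-chlorofuran-2-yl in place of furan-3-yl gives a 1.0-fold lower number from compound 3 to compound 4 (0.00 log units; within the scatter) and so leaves that exchange without a readable effect either. Nothing measured alongside these numbers bears on why both exchanges leave the read-out level.

On these data alone, compound 2 and compound 4 both carry a chlorine on this phenyl ring, so it remains open whether the chlorine itself counts for anything, a question that a plain phenyl or a phenyl bearing a methoxy group, an amine or a carboxylic acid would address. Also open, as far as these compounds go, is whether any group at this place, such as a basic aminomethyl chain or a pyridine ring, can move the number beyond the scatter at all in this assay and away from the level shared by these compounds.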